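Indole methylation of the nitrophenyl analogue

This account rests on a few compounds, and the source may have more. Where it says the series, first, only, none or still open, it means among the compounds named here.

Compound 1 `O=C1C(O)=C(C(c2ccc([N+](=O)[O-])cc2)c2c[nH]c3ccccc23)C(=O)c2ccccc21` is read in a toxicity assay (Homo sapiens) for cytotoxicity, read by MTT assay, with a stated time of 48 h (on this read-out higher numbers stand for weaker inhibition and lower numbers for stronger inhibition), only as a limit: compound 1 gives > 200000 nM. Compound 1 thus sits at the limit of > 200000 nM in this assay, at which 2 of the 3 values shown sit. Compound 2 `COc1ccccc1C(C1=C(O)C(=O)c2ccccc2C1=O)c1c[nH]c2ccccc12` also reaches only a limit, and compound 2 gives > 200000 nM. Compound 3 `O=C1C(O)=C(C(c2cccs2)c2c[nH]c3ccccc23)C(=O)c2ccccc21` gives a number, 31300 nM. The three measured steps all alter the aryl group on the saturated chain carbon bound to an aromatic carbon and a double-bonded ring carbon: the exchange to 2-methoxyphenyl shows a step that the two limits leave unreadable from compound 1 to compound 2, while the exchange to thiophen-2-yl shows an at least 6.3-fold lower number from compound 1 to compound 3 (0.80 log units; beyond the scatter) and an at least 6.3-fold lower number from compound 2 to compound 3 (0.80 log units; beyond the scatter).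

Compound 4 `Cc1[nH]c2ccccc2c1C(C1=C(O)C(=O)c2ccccc2C1=O)c1ccc([N+](=O)[O-])cc1` differs from compound 1 by methyl in place of hydrogen on an aromatic carbon, read one bond further out as 1H-indol-3-yl to 2-methyl-1H-indol-3-yl. Within the data shown here, no measured step touches this ring; every measured step concerns the aryl group on the saturated chain carbon, so none of them gives a reading for the present change. The step from compound 1 to compound 4 is therefore expected to be a number no higher from compound 1 to compound 4 (the limit leaves the size open), that is, nothing beyond the scatter. Compound 4 is estimated at 200000 nM, between 80000 nM and 500000 nM, with the outcome most likely again reported only as a limit.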

Compound 4, half-maximal inhibitory concentration: 15100 nM
For compound 4 the middle estimate is 13-fold (1.12 log units) above the measured one; the whole stated range lies above it.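

In this assay, methyl in place of hydrogen on an aromatic carbon of the five-membered aromatic ring, next to the ring nitrogen and next to the ring atom that bears a large group, gives an at least 13-fold lower number from compound 1 to compound 4 (1.12 log units; beyond the scatter). Among these compounds, this is the first reading at this position, as all earlier steps concerned the aryl group on the saturated chain carbon, and it shows that the change from 1H-indol-3-yl to 2-methyl-1H-indol-3-yl alone is enough for the 4-nitrophenyl compound to give a number, with compound 4 at 15100 nM. The full size of the step stays unknown because compound 1 is recorded only as a limit: the limit of > 200000 nM in this assay, at which 2 of the 4 values shown sit.

The compounds shown leave open whether the methyl step carries over when 2-methoxyphenyl or thiophen-2-yl sits on the saturated chain carbon. Also open, going by these compounds, is whether an ethyl group, a longer chain or an amine on the same aromatic carbon would behave as methyl does, and whether methyl on the ring nitrogen would give any comparable step.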